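Adding a second propylamino group to a non-toxic core

A few compounds are considered here, and "the series" means these few. Any claim that something is new, unique, unknown or untested is made for them only; others in the source may bear on it.

Compound 1 `CCCNc1ncnc2c1cnn2-c1ccccc1` carries a single propylamino group on the shared core. In a functional assay on G-361 cells (Homo sapiens) for cytotoxicity, read by sulforhodamine B assay (a lower number here means that less compound is tolerated, a higher number that more compound is tolerated), compound 1 gives > 100000 nM, which is a limit of the assay rather than a measured number. Compound 1 therefore has no settled position among the values shown; it simply sits at the limit, as do the two other measured compounds. Compound 2 `Cc1nc(NC(C)C)c2cnn(-c3ccccc3)c2n1` differs from compound 1 in more than one place, and in this assay compound 2 gives > 100000 nM, again a limit. Compound 3 `CCc1nc(NC(C)C)c2cnn(-c3ccccc3)c2n1` lengthens the methyl of compound 2 to an ethyl, and in this assay compound 3 gives > 100000 nM, also a limit. Within the data shown here, the only step between neighbouring measured compounds, a step that the two limits leave unreadable from compound 2 to compound 3, cannot be sized, as both of its values rest at the limit of > 100000 nM in this assay, at which 3 of the 3 values shown sit.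

Compound 4 `CCCNc1nc(NCCC)c2cnn(-c3ccccc3)c2n1` is reached from compound 1 by propylamino in place of hydrogen on an aromatic carbon. Among the measured compounds shown here, no measured step touches this change directly, and the single step available is unreadable. The expectation is therefore that compound 4 stays at the limit, with the step of a number no higher from compound 1 to compound 4 (the limit leaves the size open) expected to show nothing beyond the scatter. Compound 4 is accordingly estimated at 100000 nM, with a range from 30000 nM to 300000 nM.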

Compound 4, concentration lethal to 50% of the cells: > 100000 nM
Compound 4 gave a limit, no number; the forecaster's own chance of this, stated with the estimate: 85%; the middle value sits exactly at the limit.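

No new step can be read from compound 1 to compound 4, because both compounds rest at the same limit: the limit of > 100000 nM in this assay, at which 4 of the 4 values shown sit.

The compounds shown leave open how far any of these changes, including the added propylamino group, shifts the tolerated concentration in this assay, where none of them gives a measured number.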